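The source may report more compounds than this note shows. Statements on the series, on what has been measured and on what is new or still open speak of the compounds shown alone.

In an ADME assay on C8166 cells (Homo sapiens) for cytotoxicity (on this read-out higher numbers stand for lower toxicity in this test and lower numbers for higher toxicity in this test), compound 1 (`CCN1C(=O)N(c2ccc(C)cc2)C(=O)N(c2ccccc2)c2cc(C(F)(F)F)ccc21`) gives > 6500 nM as its result, which is a limit and not a number. Compound 2 (`CCN1C(=O)N(c2ccc(C(=O)NC)cc2)C(=O)N(c2ccccc2)c2cc(C(F)(F)F)ccc21`) gives 31000 nM in this assay and is the only close relative here with a true number.

The change followed now leads to compound 3 (`CCN1C(=O)N(c2cc(C)c(O)c(Cl)c2)C(=O)N(c2ccccc2)c2cc(C(F)(F)F)ccc21`), with 3-chloro-4-hydroxy-5-methylphenyl in place of 4-methylphenyl on an amide-type nitrogen in a ring. Among the compounds with values here, the one measured change on that same 4-methylphenyl group, methylcarbamoyl in place of methyl, is a step that the limit leaves unreadable from compound 1 to compound 2 and so offers no size to carry over.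

With no readable step to lean on, no firm direction can be argued, and no large shift is expected in this assay for this swap. Within the data shown here, the best guide is the one real number, so compound 3 is expected to fall in the same broad region as compound 2 at 31000 nM on this scale, perhaps somewhat lower. For compound 3 the estimated value is 15000 nM within an expected range of 5000 nM to 45000 nM as a wide band. This estimate means an expected step that the limit leaves unreadable from compound 1 to compound 3 for the swap.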

Compound 3, half-maximal cytotoxic concentration: > 10000 nM
Compound 3: a limit, no number; the forecaster's own chance of this, stated with the estimate: 35%; the middle value lies beyond the limit too.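

No step can be read from compound 1 or compound 2 to compound 3, as the result of compound 3 in this assay is a limit and not a number, and so is that of compound 1. The compounds shown leave open whether swapping 4-methylphenyl for 3-chloro-4-hydroxy-5-methylphenyl changes the cytotoxic concentration at all, and by how much.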